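The source may report more compounds than this note shows. Statements on the series, on what has been measured and on what is new or still open speak of the compounds shown alone.

Measured so far:
compound 1, `CCCc1nc(C(F)(F)F)ccc1CNC(=O)C(C)c1ccc(NS(C)(=O)=O)c(F)c1`: 22.7 nM
compound 2, `CC(C(=O)NCc1ccc(C(F)(F)F)nc1C1CCC(F)(F)CC1)c1ccc(NS(C)(=O)=O)c(F)c1`: 1.5 nM

In an assay on CHO cells for antagonist activity at transient receptor potential cation channel subfamily V member 1 (Homo sapiens), read by FLIPR and calcium flux (a lower number here means a stronger inhibitor, a higher number a weaker inhibitor), compound 2 stands at the lowest of the two numbers, compound 1 at the higher one. Compound 3, `CCC/C=C\c1nc(C(F)(F)F)ccc1CNC(=O)C(C)c1ccc(NS(C)(=O)=O)c(F)c1`, carries the change (pent-1-en-1-yl in place of 4,4-difluorocyclohexyl on an aromatic carbon). Among the measured compounds shown here, the only measured step at this position is a 15-fold lower number from compound 1 to compound 2 (1.18 log units; beyond the scatter), a large one. The entering chain is nearer the propyl of compound 1 than to the ring of compound 2, so a move back toward the weaker side is expected, though not the whole way; the expected step is a 5.3-fold higher number from compound 2 to compound 3 (0.73 log units; beyond the scatter). For compound 3 the estimate in this assay is 8 nM, within 3 nM to 25 nM.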

Compound 3, inhibition constant: 2.1 nM
Estimate against measurement, compound 3: 3.8-fold (0.58 log units) above; measured number outside the range, below it.
By their numbers in this assay, from the lowest: compounds 2 and 3 (each within the scatter of the next); then compound 1.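

In this assay pent-1-en-1-yl in place of 4,4-difluorocyclohexyl gives a 1.4-fold higher number from compound 2 to compound 3 (0.15 log units; within the scatter) and no real separation, so a low number at this position does not need a ring. Pent-1-en-1-yl in place of propyl gives an 11-fold lower number from compound 1 to compound 3 (1.03 log units; beyond the scatter) and shows that an open chain can also move well away from propyl.

As far as these compounds go, whether the double bond or the chain length carries this gain stays open, and a saturated pentyl chain would separate the two. No measurement at hand explains either step.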